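Swapping chloro for fluoro on the anilide ring

The compounds below may be only part of what the source reports. "The series", "measured", "known", "first", "only" and "open" are said of these compounds alone.

Compound 1 `O=C(Nc1ccc(C(F)(F)F)cc1)c1cc(Cl)ccc1O` gives 2800 nM in an ADME assay on cells (Macrophage, Mus musculus) for cytotoxicity, read by resazurin assay, with a stated time of 3 days; a lower number here means a stronger inhibitor, a higher number a weaker inhibitor. Compound 3 `O=C(Nc1ccc(C(F)(F)F)cc1)c1cc(F)ccc1O` carries fluoro in place of chloro on an aromatic carbon on the core of compound 1, and in this assay compound 3 gives 5400 nM, a step of a 1.9-fold higher number from compound 1 to compound 3 (0.29 log units; within the scatter). Compound 2 `O=C(Nc1cc(C(F)(F)F)ccc1Cl)c1cc(F)ccc1O` has a different core; the difference between the two cores is not broken down here. In this assay compound 2 gives 6100 nM. Compound 4 `O=C(Nc1cc(C(F)(F)F)ccc1F)c1cc(F)ccc1O` differs from compound 2 by fluoro in place of chloro on an aromatic carbon, the same kind of change, though here the place is ortho to a large group and para to a trifluoromethyl group rather than meta to a large group and para to a hydroxy group. For compound 4 the expected step is a 1.5-fold higher number from compound 2 to compound 4 (0.17 log units; within the scatter), resting on the step from compound 1 to compound 3 a 1.9-fold higher number from compound 1 to compound 3 (0.29 log units; within the scatter). Compound 4 is estimated at 9000 nM, expected between 4000 nM and 20000 nM.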

Compound 4, half-maximal inhibitory concentration: 5100 nM
Compound 4: middle estimate off by 1.8-fold (0.25 log units), on the high side; the range from low to high includes it.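

In this assay, fluoro in place of chloro on the core of compound 2 gives a 1.2-fold lower number from compound 2 to compound 4 (0.08 log units; within the scatter) and so stays inside the usual scatter of repeat measurements. Within that scatter, this series gives no sign that the change behaves differently on the two cores, though two small steps are too little to show that it is without effect or that it would carry to a third core. Set side by side, the two steps do not separate: the same change on two cores in this assay, a 1.9-fold higher number (0.29 log units; within the scatter) from compound 1 to compound 3 and a 1.2-fold lower number (0.08 log units; within the scatter) from compound 2 to compound 4, 2.3-fold (0.36 log units) apart, within the scatter of two such steps.

The compounds shown leave open what other groups at this place, such as a methoxy group or a nitrile, would do. They also leave open whether the swap would read the same with an amine in place of the hydroxy group.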